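Ribose in place of deoxyribose on an inactive core

The source may hold more compounds than are shown below. What is called first, only, known or untested is meant among the compounds shown, and "the series" means these compounds.

Compound 1 `Cc1nsc2c1nc(SCc1ccccc1)n2[C@H]1C[C@H](O)[C@@H](CO)O1` sets the reference point. In a functional assay on KB cells (Homo sapiens) for antiproliferative activity (on this read-out higher numbers stand for weaker inhibition and lower numbers for stronger inhibition), compound 1 gives > 100000 nM, which is a limit of the assay and not a number. Compound 2 `OC[C@H]1O[C@@H](n2c(SCc3ccccc3)nc3cnsc32)C[C@@H]1O` differs by hydrogen in place of methyl on an aromatic carbon. In this assay compound 2 gives > 100000 nM, again a limit. Within the data shown here, the step that the two limits leave unreadable from compound 1 to compound 2 is therefore unreadable, and the only evidence on the measured compounds is the limit of > 100000 nM in this assay, at which 2 of the 2 values shown sit.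

Compound 3 `Cc1nsc2c1nc(SCc1ccccc1)n2[C@@H]1O[C@H](CO)[C@@H](O)[C@H]1O` carries the change (hydroxy in place of hydrogen on a saturated ring carbon), with the place as described. Among the measured compounds shown here, no measured step bears on this change; the one measured step is itself unreadable. The expectation for compound 3 rests on compound 1 alone, whose value in this assay is a limit, so the step of a number no higher from compound 1 to compound 3 (the limit leaves the size open) is estimated to stay at or near that limit. Compound 3 is expected at 100000 nM, within 30000 nM to 300000 nM.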

Compound 3, half-maximal inhibitory concentration: > 100000 nM
Compound 3 was reported as a limit; the forecaster's own chance of this, stated with the estimate: 80%; the middle value sits exactly at the limit.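

The step between compound 1 and compound 3 cannot be read, as each of the two is reported only as a limit of the assay: the limit of > 100000 nM in this assay, at which 3 of the 3 values shown sit. From the compounds shown here alone, whether hydroxy in place of hydrogen on a saturated ring carbon changes the result in this assay at all stays open.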